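This account rests on a few compounds, and the source may have more. Where it says the series, first, only, none or still open, it means among the compounds named here.

In a toxicity assay on HEK293 cells (Homo sapiens) for inhibition, read by resazurin assay, with a stated time of 24 h (a higher number here means that more compound is tolerated, a lower number that less compound is tolerated), compound 1 `Cn1c([N+](=O)[O-])cnc1C(=O)NC1CC1` gives > 100000 nM, which is a limit of the assay. Compound 2 `Cn1c([N+](=O)[O-])cnc1C(=O)NC1CCCCC1` gives > 100000 nM, so it too stands only at a limit. Compound 3 `CN(C)C(=O)c1ncc([N+](=O)[O-])[nH]1`, which carries hydrogen on the aromatic nitrogen, gives > 100000 nM, again a limit. Compound 4 `O=C(NC1CCCCC1)c1ncc([N+](=O)[O-])[nH]1` differs from compound 2 by hydrogen in place of methyl on an aromatic nitrogen. Going by the values given here, the one measured step is a step that the two limits leave unreadable from compound 1 to compound 2, and it concerns a different place, on an amide-type nitrogen. The remaining evidence is the limit of > 100000 nM in this assay, at which 3 of the 3 values shown sit. No step beyond the scatter is therefore expected, and the estimated change is a number no higher from compound 2 to compound 4 (the limit leaves the size open). For compound 4 the expected value is 100000 nM, with an estimated range of 60000 nM to 200000 nM.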

Compound 4, half-maximal cytotoxic concentration: > 100000 nM
Compound 4 gave a limit, no number (the forecaster's own chance of this, stated with the estimate: 85%); the middle value sits exactly at the limit.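

Compound 2 and compound 4 each stand only at a limit, so no step can be read for hydrogen in place of methyl on the aromatic nitrogen. The compounds shown leave open at what concentration any of the four stops being tolerated.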